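This account rests on a few compounds, and the source may have more. Where it says the series, first, only, none or still open, it means among the compounds named here.

Values in a functional assay (aorta) with Oryctolagus cuniculus as the target; on this read-out higher numbers stand for weaker binding and lower numbers for tighter binding:

- Compound 1 `N#Cc1ccc(OCCCN2CCC(C(c3ccc(F)cc3)c3ccc(F)cc3)CC2)cc1` gives 5.01 nM
- Compound 2 `Fc1ccc(C(c2ccc(F)cc2)C2CCN(CCCOc3ccc(Br)cc3)CC2)cc1` gives 1.59 nM
- Compound 3 `CC(=O)Nc1ccc(OCCCN2CCC(C(c3ccc(F)cc3)c3ccc(F)cc3)CC2)cc1` gives 12.6 nM

Among these three, compound 3 has the highest number, 12.6 nM, so it is the weakest binder of the set. Compound 4 `Fc1ccc(C(c2ccc(F)cc2)C2CCN(CCCOc3cccc4ccccc34)CC2)cc1` replaces its 4-acetamidophenyl group with naphthalen-1-yl on the same oxygen: naphthalen-1-yl in place of 4-acetamidophenyl on an oxygen on a saturated carbon.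

Among the measured compounds shown here, two measured steps bear on this change, as both introduce the acetamido group: a 2.5-fold higher number from compound 1 to compound 3 (0.40 log units; beyond the scatter) and a 7.9-fold higher number from compound 2 to compound 3 (0.90 log units; beyond the scatter). For the measured compounds named here, each raised the number, and no compound here goes against that. Removing the group should therefore lower the number by a step of similar size. The bromo and cyano compounds also differ from each other, a 3.2-fold lower number from compound 1 to compound 2 (0.50 log units; beyond the scatter), so the replacement group matters. Going by the values given here, no compound with naphthalen-1-yl has been measured, which keeps the range wide.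

The expected change is a 4.2-fold lower number from compound 3 to compound 4 (0.62 log units; beyond the scatter). For compound 4 the estimated value is 3 nM, with an expected range from 0.9 nM to 10 nM.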

Compound 4, dissociation constant: 5.01 nM
Estimate against measurement, compound 4: 1.7-fold (0.22 log units) below, and the stated range covers the measured number.
By their numbers in this assay, from the lowest: compound 2; then compounds 1 and 4 (each within the scatter of the next); then compound 3.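

The earlier compounds shown here changed only a substituent on one phenyl ring, whereas compound 4 shows that in this assay a naphthalen-1-yl group, with two aromatic rings of carbon only, can stand on this oxygen without leaving the range of those compounds: the change gives a 2.5-fold lower number from compound 3 to compound 4 (0.40 log units; beyond the scatter) and a 3.2-fold higher number from compound 2 to compound 4 (0.50 log units; beyond the scatter). Set against 4-cyanophenyl, the same group gives no change at the digits printed from compound 1 to compound 4 (within the scatter) so the two groups cannot be told apart on this read-out. Nothing at hand says why these steps have the sizes they do.

The compounds shown leave open how a naphthalen-2-yl group or an unsubstituted phenyl would read on the same oxygen. They also leave open whether a longer chain carrying naphthalen-1-yl would shift the number.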